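Adding a Phenyl Ring to the Amino Acid Side Chain

The compounds below may be only part of what the source reports. "The series", "measured", "known", "first", "only" and "open" are said of these compounds alone.

Compound 1 `COC(=O)C(Nc1cc(NS(=O)(=O)/C=C/c2c(OC)cc(OC)cc2OC)ccc1OC)c1ccc(Cl)cc1` gives 5000 nM in a functional assay on DU-145 cells (Homo sapiens) for cytotoxicity, read by trypan blue exclusion, with a stated time of 96 h; on this read-out higher numbers stand for weaker inhibition and lower numbers for stronger inhibition.
Compound 2 `COc1cc(OC)c(/C=C/S(=O)(=O)Nc2ccc(OC)c(NCC(=O)O)c2)c(OC)c1` gives 400 nM in this assay.

Compound 2 has the lowest number of the two measured, with compound 1 giving a higher one. Compound 3 `COc1cc(OC)c(/C=C/S(=O)(=O)Nc2ccc(OC)c(NC(C(=O)O)c3ccccc3)c2)c(OC)c1` differs from compound 2 by phenyl in place of hydrogen on a saturated chain carbon bound to a carbonyl carbon and a nitrogen on an aromatic ring. Within the data shown here, the only measured step, a 13-fold lower number from compound 1 to compound 2 (1.10 log units; beyond the scatter), removed a ring and an ester at this place together; compound 3 brings back only the ring, so part of that step is expected to be undone. For compound 3 in this assay the expected step is a 3.0-fold higher number from compound 2 to compound 3 (0.48 log units; beyond the scatter), giving an estimated 1200 nM with a range of 400 nM to 4000 nM.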

Compound 3, half-maximal inhibitory concentration: 75 nM
Compound 3: middle estimate off by 16-fold (1.20 log units), on the high side, outside the stated range (below it).
By their numbers in this assay, from the lowest: compound 3; then compound 2; then compound 1.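

Placing phenyl on this saturated chain carbon does more than keep activity: in this assay it gives a 5.3-fold lower number from compound 2 to compound 3 (0.73 log units; beyond the scatter). A ring at this place therefore does not by itself bring the high number of compound 1, and the change to carboxy(phenyl)methyl gives a 67-fold lower number from compound 1 to compound 3 (1.82 log units; beyond the scatter). No measurement here explains the effect of the phenyl.

That larger step changes both the chlorine and the methyl ester, and the compounds shown do not separate their shares. As far as these compounds go, how a benzyl group or a cyclohexyl ring would compare with phenyl on this carbon also remains open.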